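Changing the Acyl Group on a Shared Core

The source may hold more compounds than are shown below. What is called first, only, known or untested is meant among the compounds shown, and "the series" means these compounds.

Of the compounds shown here, two have so far been measured in a functional assay on PC-3 cells (Homo sapiens) for cytotoxicity, read by MTT assay, with a stated time of 48 h; a lower number here means a stronger inhibitor, a higher number a weaker inhibitor. Compound 1 `CCC(=O)N1N=C(C)CC1c1cc(Br)cc(Br)c1O` gives 28600 nM. Compound 2 `CC1=NN(C(=O)CCc2ccccc2)C(c2cc(Br)cc(Br)c2O)C1` gives 11300 nM in this assay. Within the data shown here, the only step between them, a 2.5-fold lower number from compound 1 to compound 2 (0.40 log units; beyond the scatter), is a modest gain. Compound 2 therefore stands as the lower of the two numbers, the stronger inhibitor of the pair by a step beyond the scatter.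

Compound 3 `CC1=NN(C(=O)c2ccc(C)cc2)C(c2cc(Br)cc(Br)c2O)C1` is the next candidate. It differs from compound 2 by 4-methylphenyl in place of phenethyl on a carbonyl carbon, so the aromatic ring now sits directly on the carbonyl carbon instead of at the end of a two-carbon chain. Among the measured compounds shown here, no measured step matches this exchange. For the measured compounds named here, the one step available shows that an aromatic ring on the acyl side, as in compound 2, goes with a lower number than none at all, as in compound 1, and both compound 2 and compound 3 keep such a ring. A step of about the scatter or slightly beyond is expected, with no firm direction. Compound 3 is therefore expected to give roughly 10000 nM, within 4000 nM to 30000 nM, which means an expected step of a 1.1-fold lower number from compound 2 to compound 3 (0.05 log units; within the scatter).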

Compound 3, half-maximal inhibitory concentration: 41200 nM
For compound 3 the middle estimate is 4.1-fold (0.61 log units) below the measured one; the whole stated range lies below it.
By their numbers in this assay, from the lowest: compound 2; then compounds 1 and 3 (each within the scatter of the next).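

On the carbonyl carbon, whose other neighbour is the amide-type nitrogen in a ring, an aromatic ring on the acyl side does not by itself go with a lower number: in this assay, 4-methylphenyl in place of phenethyl gives a 3.6-fold higher number from compound 2 to compound 3 (0.56 log units; beyond the scatter), a step beyond the scatter. Set against ethyl at the same place, 4-methylphenyl gives a 1.4-fold higher number from compound 1 to compound 3 (0.16 log units; within the scatter), a step within the scatter, so among these three compounds only compound 2, with its ring at the end of a chain, stands apart from the others. Nothing measured here explains why the chain-linked ring goes with the lower number.

The exchange from phenethyl to 4-methylphenyl removes the chain and adds a methyl group on the ring in a single step, so the compounds shown cannot tell which of the two changes accounts for the higher number. A plain phenyl on the carbonyl carbon would separate those two changes, and a longer chain ending in phenyl would show whether the number keeps falling as the ring moves further from the carbonyl carbon.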